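Inversion of one ring stereocentre in a pentadecyl sugar ether

The source may hold more compounds than are shown below. What is called first, only, known or untested is meant among the compounds shown, and "the series" means these compounds.

Measured compounds:
- compound 1 `O[C@@H]1[C@@H](OCc2ccccc2)[C@H](O)[C@@H](COCc2ccccc2)O[C@H]1Cc1ccccc1`: 35300 nM
- compound 2 `C#CC[C@@H]1O[C@H](COCc2ccccc2)[C@@H](OCc2ccccc2)[C@H](OCc2ccccc2)[C@H]1O`: "not active" (no number reported)
- compound 3 `CCCCCCCCCCCCCCCOC[C@H]1O[C@H](CCC)[C@H](O)[C@@H](OCCCCCCCCCCCCCCC)[C@@H]1OCCCCCCCCCCCCCCC`: "not active" (no number reported)

Three sugar ethers have been run in a functional assay on HL-60 cells (Homo sapiens) for antiproliferative activity, read by MTT assay; a lower number here means a stronger inhibitor, a higher number a weaker inhibitor. Within the data shown here, compound 1, the tri-benzylated member, gives 35300 nM in this assay, the only single number in the set. Compound 2 in this assay is reported as "not active" (no number reported). Compound 3, the fully pentadecylated member, is reported in this assay as "not active" (no number reported), so compound 3 stands without a single number, and one further compound of the set shares that state.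

Compound 4 `CCCCCCCCCCCCCCCOC[C@H]1O[C@@H](CCC)[C@H](O)[C@@H](OCCCCCCCCCCCCCCC)[C@@H]1OCCCCCCCCCCCCCCC` is the next member to be measured. It differs from compound 3 as follows: the two compounds have the same atoms and bonds and differ only in configuration as drawn: 1 of 5 stereo elements differ; a stereocentre at a saturated ring carbon is drawn R in compound 3 and S in compound 4

Among the measured compounds shown here, no step between two measured compounds is available, so the size of this change cannot be read from the series. Since compound 3 has no number in this assay, the reference point is itself a report of no activity. The expectation for compound 4 is no step beyond the scatter in either direction, and most probably a report without a number again.

Compound 4 is expected to give about 60000 nM in this assay, with a range from 20000 nM to 200000 nM.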

Compound 4, half-maximal inhibitory concentration: "not active" (no number reported)
Compound 4 has no reported number here, so the estimate cannot be set against anything.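

No new step can be read: in this assay, compound 3 and compound 4 are both reported as not active, with no number for either. The pair is closely matched: the fact that compounds 3 and 4 differ only in the configuration as drawn. The compounds shown leave open whether inverting this stereocentre changes antiproliferative activity at all.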